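Ethoxy for methoxy on the aryl of compound 1

The source may report more compounds than this note shows. Statements on the series, on what has been measured and on what is new or still open speak of the compounds shown alone.

Values in a functional assay on HeLa cells (Homo sapiens) for antiproliferative activity, read by MTT assay, with a stated time of 72 h; on this read-out higher numbers stand for weaker inhibition and lower numbers for stronger inhibition:
compound 1 `COc1ccccc1-c1ncnn1-c1cc(OC)c(OC)c(OC)c1`: > 10000 nM, a limit of the assay, not a number
compound 2 `COc1cc(-n2ncnc2-c2ccc(F)cc2)cc(OC)c1OC`: > 10000 nM, likewise a limit
compound 3 `COc1cc(-n2ncnc2-c2ccc(C)cc2)cc(OC)c1OC`: 250 nM

Compound 1 stands at the limit of this assay; that is all the numbers show for it, and the limit of > 10000 nM in this assay, at which 2 of the 3 values shown sit, holds two of the three values. The measured steps all turn on the aryl group attached to the shared core: a step that the two limits leave unreadable from compound 1 to compound 2, an at least 40-fold lower number from compound 1 to compound 3 (1.60 log units; beyond the scatter) and an at least 40-fold lower number from compound 2 to compound 3 (1.60 log units; beyond the scatter).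

Compound 4 `CCOc1ccccc1-c1ncnn1-c1cc(OC)c(OC)c(OC)c1` differs from compound 1 by methyl in place of hydrogen on a saturated chain carbon bound to an oxygen on an aromatic ring. For the measured compounds named here, none of the measured steps touches this position, so no step bears directly on the change. What compound 1 shows is a limit, and the change is a single carbon added to the methoxy group. Compound 4 is therefore expected to remain near the limit, at 12000 nM with a range of 2500 nM to 60000 nM. The expected step is a step that the limit leaves unreadable from compound 1 to compound 4, within the scatter and most likely again reported only as a limit.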

Compound 4, half-maximal inhibitory concentration: > 10000 nM
Compound 4: no number, only a limit; the forecaster's own chance of this, stated with the estimate: 70%; the middle value lies beyond the limit too.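

Compound 1 and compound 4 each give only a limit, not a number, so no step between them can be read: the limit of > 10000 nM in this assay, at which 3 of the 4 values shown sit.

Still open, from the compounds shown here alone, is what methoxy to ethoxy does on a compound whose value lies clear of that limit.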